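This account rests on a few compounds, and the source may have more. Where it says the series, first, only, none or still open, it means among the compounds named here.

Among the compounds with values here, compound 3 `COC(=O)/C=C/c1cccc(N(Cc2ccc(/C=C/c3scnc3C)cc2)C(=O)C(C)C)c1` in an assay on isolated protein with Bile acid receptor (Homo sapiens) as the target (a lower number here means that less compound is needed, a higher number that more compound is needed for the effect), gives 228 nM, the second highest of the three numbers known for the series. Its nearest neighbour is compound 2 `COC(=O)/C=C/c1cccc(N(Cc2ccc(/C=C/c3scnc3C)cc2)C(=O)C2CCCCC2)c1`, which in this assay gives 227 nM, and the two lie within the scatter. Furthest away is compound 1 `COC(=O)/C=C/c1cccc(N(Cc2ccc(/C=C/c3cc(C(F)(F)F)cc(C(F)(F)F)c3)cc2)C(=O)C(C)C)c1`, which gives 1950 nM, a number beyond the scatter from compound 3. Within the data shown here, the only single-point step measured so far is a 1.0-fold higher number from compound 2 to compound 3 (0.00 log units; within the scatter), a change at the carbonyl carbon and not at the aryl terminus.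

On these data alone, compound 4 `COC(=O)/C=C/c1cccc(N(Cc2ccc(-c3ccc(N(C)C)cc3)cc2)C(=O)C(C)C)c1` is untested. It differs from compound 3 by 4-(dimethylamino)phenyl in place of 2-(4-methyl-1,3-thiazol-5-yl)ethenyl on an aromatic carbon. Among the measured compounds shown here, no measured step touches this position; the pair compound 1 and compound 3 differs there too, but by more than one change, so their values only show that the terminus can move the number substantially. For the measured compounds named here, with no direct precedent, a moderate weakening is expected in this assay, a 2.6-fold higher number from compound 3 to compound 4 (0.42 log units; beyond the scatter), with wide uncertainty. Compound 4 is therefore estimated at 600 nM, within 150 nM to 3000 nM.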

Compound 4, half-maximal effective concentration: 57 nM
For compound 4 the middle estimate is 11-fold (1.02 log units) above the measured one, outside the stated range (below it).
By their numbers in this assay, from the lowest: compound 4; then compounds 2 and 3 (each within the scatter of the next); then compound 1.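

In this assay the aromatic carbon para to a large group now has a direct single-point step: 4-(dimethylamino)phenyl in place of 2-(4-methyl-1,3-thiazol-5-yl)ethenyl gives a 4.0-fold lower number from compound 3 to compound 4 (0.60 log units; beyond the scatter) and so lies beyond the scatter, unlike the step at the carbonyl carbon. In this pair, neither the five-membered aromatic ring with 2 hetero atoms nor the double bond outside aromatic rings is needed to reach a lower number. No measurement on hand bears on the reason for this step.

The change replaces the ring and the double bond together, so their separate contributions to the step remain unresolved. Also open, on these data alone, is whether a methoxy group or a morpholine in place of the dimethylamino group would hold the number, and whether an ethenyl link to the 4-(dimethylamino)phenyl would change it.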